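Working notes: from compound 1 to compound 4

A few compounds are considered here, and "the series" means these few. Any claim that something is new, unique, unknown or untested is made for them only; others in the source may bear on it.

Measured so far:
compound 1 `O=C(NCCCCc1ccccc1)n1c(=O)oc2cc(-c3ccc(F)cc3)ccc21`: 79 nM in an assay on HEK293 cells for inhibition of acid ceramidase (Homo sapiens), with a stated time of 10 min; a lower number here means a stronger inhibitor, a higher number a weaker inhibitor
compound 2 `O=C(NCCCc1ccccc1)n1c(=O)oc2ccccc21`: 55 nM
compound 3 `O=C(NCCCCc1ccc2ccccc2c1)n1c(=O)oc2ccccc21`: 71 nM

Compound 1 gives the highest number of the three in this assay, but its gaps to compound 3 and to compound 2 both lie within the scatter, so the three stand level. Compound 4 `O=C(NCCCCc1ccccc1)n1c(=O)oc2cc([N+](=O)[O-])ccc21` differs from compound 1 in one place: nitro in place of 4-fluorophenyl on an aromatic carbon. Among the compounds with values here, no pair of measured compounds differs in exactly one place, so no measured step guides this change. Compounds 2 and 3 carry no group on the shared core and still give numbers level with compound 1, which shows that the 4-fluorophenyl is not needed for a number in this range. What the nitro group does when it enters is not shown by any measured compound. The expected step of a 1.2-fold lower number from compound 1 to compound 4 (0.08 log units; within the scatter) is therefore small, not beyond the scatter, with a wide range allowed either way. Compound 4 is estimated at 65 nM in this assay, from 20 nM to 250 nM.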

Compound 4, half-maximal inhibitory concentration: 3 nM
Estimate against measurement, compound 4: 22-fold (1.34 log units) above, and the stated range ends above it.
By their numbers in this assay, from the lowest: compound 4; then compounds 2, 3 and 1 (each within the scatter of the next).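

In this assay, within the data shown here, nitro in place of 4-fluorophenyl gives a 26-fold lower number from compound 1 to compound 4 (1.42 log units; beyond the scatter) and this is the first measured step, one well beyond the scatter. The earlier compounds shown here gave no reading of this aromatic carbon, and the step now shows that the number depends strongly on the group placed there, with the change from a ring-bearing group to nitro, which has no ring, moving it far more than the differences among the earlier compounds. No measurement at hand accounts for the step, and it cannot be divided between the departure of the 4-fluorophenyl and the entry of the nitro.

From the compounds shown here alone, it remains open whether an amine, a nitrile or a carboxylic acid at this carbon would give a number like that of compound 4. Among these compounds, also open is whether the step would hold with a longer chain in place of the one on compound 4.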